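The source may report more compounds than this note shows. Statements on the series, on what has been measured and on what is new or still open speak of the compounds shown alone.

Working notes on the series. In a functional assay on WM1361 cells (Homo sapiens) for inhibition, read by MTT assay, with a stated time of 24 h (a higher number here means a weaker inhibitor, a lower number a stronger inhibitor), compound 1 (`COc1cccc(N2CCN(c3c(CO)c(=O)oc4ccccc34)CC2)c1`) gives 38100 nM as its reading, and compound 3 (`O=c1oc2ccccc2c(N2CCN(c3ccc(Cl)c(Cl)c3)CC2)c1CO`) gives 42700 nM as its reading.

Compound 2 (`O=c1oc2ccccc2c(N2CCN(c3ccccc3)CC2)c1CO`) gives > 50000 nM as its reading, which is a limit of the assay and not a number. Compound 2 therefore stands at the limit of > 50000 nM in this assay, at which 1 of the 3 values shown sits, and has no measured position of its own.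

Compound 4 (`O=c1oc2ccccc2c(N2CCN(c3cccc(C(F)(F)F)c3)CC2)c1CO`) differs from compound 2 by a single change: trifluoromethyl in place of hydrogen on an aromatic carbon with trifluoromethyl in place of hydrogen on an aromatic carbon.

Among the measured compounds shown here, the steps that bear on this are the other changes on that aromatic ring. These are an at least 1.3-fold higher number from compound 1 to compound 2 (0.11 log units; that floor lies within the scatter) and an at least 1.1-fold lower number from compound 2 to compound 3 (0.06 log units; that floor lies within the scatter) and also a 1.1-fold higher number from compound 1 to compound 3 (0.05 log units; within the scatter) as the step between the two substituted compounds. The two steps touching compound 2 are floors only, so they do not fix a size. On this evidence, no step beyond the scatter is expected in this assay for the new group, and any movement would be expected toward a lower number, as the direction of the floor in an at least 1.1-fold lower number from compound 2 to compound 3 (0.06 log units; that floor lies within the scatter) allows.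

The estimated step is an at least 1.1-fold lower number from compound 2 to compound 4 (0.07 log units; that floor lies within the scatter) on that reasoning. For compound 4 the expected value is 42000 nM with an estimated range of 25000 nM to 70000 nM in this assay. An outcome that is only a limit is also expected to remain possible.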

Compound 4, half-maximal inhibitory concentration: > 50000 nM
Compound 4 ended at the assay's limit; the forecaster's own chance of this, stated with the estimate: 35%; middle value at least 1.1-fold (0.07 log units) away from the limit.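

In this assay compound 4 gives > 50000 nM, which is a limit of the assay and not a number. Compound 4 therefore joins compound 2 at the limit, so trifluoromethyl on this aromatic carbon, meta to a large group, gives no measured position, and a substituent on this ring does not by itself bring the reading inside the range of this assay: the limit of > 50000 nM in this assay, at which 2 of the 4 values shown sit. Replacing methoxy with trifluoromethyl gives an at least 1.3-fold higher number from compound 1 to compound 4 (0.11 log units; that floor lies within the scatter), so only a floor is available and no size is fixed, while the step from hydrogen to trifluoromethyl has a limit at both ends and cannot be read.

On these data alone, how compound 2 and compound 4 stand relative to each other remains open, as does any real difference between either of them and compound 1. Also open, as far as these compounds go, is whether an amine or a carboxylic acid on this aromatic carbon would give a reading that stands clear of compound 1 by more than the scatter.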